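Cinnamamide series, HeLa cytotoxicity: step from compound 2 to compound 3

This account rests on a few compounds, and the source may have more. Where it says the series, first, only, none or still open, it means among the compounds named here.

Measured so far:
compound 2 `O=C(/C=C/c1cccc(Cl)c1Cl)Nc1cc2c(Nc3ccc(F)c(Cl)c3)ncnc2cc1O[C@H]1CCOC1` — 30500 nM
compound 1 `COc1ccc(OC)c(/C=C/C(=O)Nc2cc3c(Nc4ccc(F)c(Cl)c4)ncnc3cc2OC)c1` — "not determined" (no result reported)

Compound 2 `O=C(/C=C/c1cccc(Cl)c1Cl)Nc1cc2c(Nc3ccc(F)c(Cl)c3)ncnc2cc1O[C@H]1CCOC1` gives 30500 nM in a functional assay on HeLa cells (Homo sapiens) for cytotoxicity, read by MTT assay, with a stated time of 72 h; on this read-out higher numbers stand for weaker inhibition and lower numbers for stronger inhibition. For the measured compounds named here, it is the only compound of the series with a number; compound 1 `COc1ccc(OC)c(/C=C/C(=O)Nc2cc3c(Nc4ccc(F)c(Cl)c4)ncnc3cc2OC)c1` stands as "not determined" (no result reported) in this assay, so compound 2 stands alone and no rank can be stated.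

Compound 3 `COc1ccc(/C=C/C(=O)Nc2cc3c(Nc4ccc(F)c(Cl)c4)ncnc3cc2O[C@H]2CCOC2)cc1` is the next entry to be measured. Its difference from compound 2 is 4-methoxyphenyl in place of 2,3-dichlorophenyl on a double-bonded chain carbon bound to a double-bonded chain carbon. Going by the values given here, no step between two measured compounds is recorded, so there is nothing here to show whether 4-methoxyphenyl in place of 2,3-dichlorophenyl moves the read-out in this assay at all, or in which direction.

Among the compounds with values here, with only one measured number, the expectation for compound 3 rests on compound 2 30500 nM and on the change alone. The step is expected to be no larger than the usual scatter, a 1.2-fold lower number from compound 2 to compound 3 (0.09 log units; within the scatter), with no preferred direction. Compound 3 is accordingly estimated at 25000 nM, within 8000 nM to 80000 nM in this assay.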

Compound 3, half-maximal inhibitory concentration: 34600 nM
The estimate for compound 3 lay 1.4-fold (0.14 log units) below the measured number; the measured number falls inside the stated range.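

Working notes on the cinnamamide series: in this assay the first readable step in the series is a 1.1-fold higher number from compound 2 to compound 3 (0.05 log units; within the scatter), so the two compounds cannot be told apart on this read-out. For this one pair, then, 4-methoxyphenyl in place of 2,3-dichlorophenyl on a double-bonded chain carbon bound to a double-bonded chain carbon gives no separation beyond the usual scatter, although two chlorine atoms leave and one oxygen enters at the same count of heavy atoms. Nothing available offers an explanation for this result.

Going by these compounds, whether a group of a different kind at this place, such as aminophenyl, carboxyphenyl or a longer chain, would separate from compound 2 in this assay remains open, since one pair of substituted phenyl groups cannot show how far this position tolerates change. Also open, on these data alone, is whether 2,3-dichlorophenyl and 4-methoxyphenyl would stay as close on the core of compound 1 , and so whether this result holds beyond the core shared by compound 2 and compound 3 .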